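Removing a Fluoro Group from a Cytotoxic Compound Series

The source may report more compounds than this note shows. Statements on the series, on what has been measured and on what is new or still open speak of the compounds shown alone.

Three compounds were tested for their effect on cancer cells: compound 1 `CCCCNc1nc(NCc2ccco2)c2ccccc2n1`, compound 3 `CCCCNc1nc(NCc2ccco2)c2cc(F)ccc2n1` and compound 2 `Fc1ccc2nc(NCCCCN3CCN(c4cccc(Cl)c4Cl)CC3)nc(NCc3ccco3)c2c1`. In a functional assay on HT-29 cells (Homo sapiens) for cytotoxicity, read by MTT assay, with a stated time of 2 days, tested at 10 uM (on this read-out higher numbers stand for more inhibition at the one concentration tested (going by the name of the read-out) and lower numbers for less inhibition), compound 1 gives 92.3%, compound 3 gives 88.1%, and compound 2 gives 96.3%; all three readings lie within the usual scatter of one another. Compound 3 and compound 1 differ in a single place, (hydrogen in place of fluoro on an aromatic carbon), and the measured change is a number 4.2 percentage points higher from compound 3 to compound 1 (within the scatter). Compound 4 `Clc1cccc(N2CCN(CCCCNc3nc(NCc4ccco4)c4ccccc4n3)CC2)c1Cl` has not yet been measured. It is related to compound 2 by the same change, (hydrogen in place of fluoro on an aromatic carbon), at a place described in identical words; how the core of compound 2 differs from the core of compound 3 is not broken down here. Because the earlier change was a number 4.2 percentage points higher from compound 3 to compound 1 (within the scatter), in this assay the read-out is expected to be a number 1.3 percentage points lower from compound 2 to compound 4 (within the scatter). Compound 4 is thus estimated to give about 95%, likely between 87% and 100%.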

Compound 4, a percentage reported as inhibition, at one concentration (the size of the read-out at that concentration, not a potency): 94.8%
Beside the measured number, compound 4's estimate is 0.2 percentage points above it; measured number inside the range.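

In this assay, putting hydrogen in place of fluoro on an aromatic carbon gives a number 1.5 percentage points lower from compound 2 to compound 4 (within the scatter). Set beside the same swap on the other core, this step cannot be told apart from the earlier one: the same change on two cores in this assay, a number 4.2 percentage points higher (within the scatter) from compound 3 to compound 1 and a number 1.5 percentage points lower (within the scatter) from compound 2 to compound 4, 5.7 percentage points apart, within the scatter of two such steps. So these two pairs give no sign that the outcome of the swap depends on the core, but two pairs cannot show that it holds for other cores, and a reading at one concentration says nothing about potency.

Still open, on these data alone, is how a chloro group or an amine would read at this place on the ring. The compounds shown also leave open what a longer chain on the core would do.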